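The compounds below may be only part of what the source reports. "The series", "measured", "known", "first", "only" and "open" are said of these compounds alone.

Measured compounds in a functional assay on HeLa cells (Homo sapiens) for inhibition, read by MTT assay, with a stated time of 24 h; a lower number here means a stronger inhibitor, a higher number a weaker inhibitor:
compound 1, `CCOC(=O)C1=Cc2ccccc2OC1(OCc1cn(CC(=O)Nc2ccc(C)cc2)nn1)C(F)(F)F`: 67400 nM
compound 2, `CCOC(=O)C1=Cc2ccccc2OC1(OCc1cn(-c2ccccc2)nn1)C(F)(F)F`: > 150000 nM
compound 3, `O=C(O)C1=Cc2ccccc2OC1(OCc1cc(-c2ccc3ccccc3c2)no1)C(F)(F)F`: > 150000 nM

In this assay compound 1 gives 67400 nM. For compound 2 the value > 150000 nM is a limit of the assay, not a number. Compound 3 likewise shows only a limit, > 150000 nM. Among the compounds with values here, the one step that can be counted, an at least 2.2-fold higher number from compound 1 to compound 2 (0.34 log units; beyond the scatter), comes from exchanging the ((4-methylphenyl)carbamoyl)methyl group on the aromatic nitrogen for phenyl; it leaves compound 2 at the weak end of what the assay can report, with the limit of > 150000 nM in this assay, at which 2 of the 3 values shown sit, marking where the bulk of the values sit.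

Compound 4, `CCOC(=O)C1=Cc2ccccc2OC1(OCc1cn(-c2ccc([N+](=O)[O-])cc2)nn1)C(F)(F)F`, differs from compound 2 in one place: nitro in place of hydrogen on an aromatic carbon. Within the data shown here, no measured step bears on a nitro group, so the only guide is the standing of compound 2 at the limit. Compound 4 is therefore expected to show no step beyond the scatter, a number no higher from compound 2 to compound 4 (the limit leaves the size open), and most likely to return a limit as well. The estimate for compound 4 in this assay is 150000 nM, with a range from 50000 nM to 400000 nM.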

Compound 4, half-maximal inhibitory concentration: > 150000 nM
Compound 4 gave a limit, no number; the forecaster's own chance of this, stated with the estimate: 65%; the middle value sits exactly at the limit.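

Compound 4 returns only a limit, > 150000 nM, so the change from phenyl to 4-nitrophenyl yields no number in this assay. Compound 2 also stands at a limit, and the step between the two cannot be read, in size or in direction. What can be read is an at least 2.2-fold higher number from compound 1 to compound 4 (0.34 log units; beyond the scatter), so a second aryl group placed directly on the aromatic nitrogen also falls short of ((4-methylphenyl)carbamoyl)methyl, the only group there that gives a number, and the series now rests largely at one value: the limit of > 150000 nM in this assay, at which 3 of the 4 values shown sit.

Left open is whether an amine or a carboxylic acid in place of the nitro group would return a number in this assay. Also open, as far as these compounds go, is which part of the ((4-methylphenyl)carbamoyl)methyl group matters, for instance whether a plain benzyl group or a longer chain on that nitrogen would give a number.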